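The source may hold more compounds than are shown below. What is called first, only, known or untested is meant among the compounds shown, and "the series" means these compounds.

Compound 1 `NC(=O)c1ncn2c(=O)n(Cc3ccccc3)nnc12` is the starting point, and in a functional assay on U-373MG ATCC cells for inhibition, with U373 MG (Homo sapiens) as the target, read by MTT assay, with a stated time of 7 days (a higher number here means a weaker inhibitor of growth, a lower number a stronger inhibitor of growth), compound 1 gives > 50000 nM, which is a limit of the assay and not a number. Two close relatives carry a methoxy in place of hydrogen on an aromatic carbon: compound 2 `COc1cccc(Cn2nnc3c(C(N)=O)ncn3c2=O)c1` and compound 3 `COc1ccc(Cn2nnc3c(C(N)=O)ncn3c2=O)cc1`. Compound 2 gives > 50000 nM, again a limit. Compound 3 gives > 50000 nM, also a limit.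

Compound 4 `Cc1cc(Cn2nnc3c(C(N)=O)ncn3c2=O)on1` keeps the core of compound 1 and differs elsewhere: 3-methyl-1,2-oxazol-5-yl in place of phenyl on a saturated chain carbon bound to an aromatic nitrogen. Put simply, this is 3-methyl-1,2-oxazol-5-yl in place of phenyl on a saturated chain carbon bound to an aromatic nitrogen.

The measured steps bear on this change only loosely, since they decorate the phenyl and do not replace it. Adding the methoxy gives a step that the two limits leave unreadable from compound 1 to compound 2, and likewise a step that the two limits leave unreadable from compound 1 to compound 3, so these steps offer no size to carry over to compound 4. Going by the values given here, with the limit of > 50000 nM in this assay, at which 3 of the 3 values shown sit, as the only evidence, no step beyond the usual scatter is expected in this assay, in either direction. The expected step, a rough estimate only, is a number no higher from compound 1 to compound 4 (the limit leaves the size open). For compound 4 the estimated value is 50000 nM, with an expected range from 20000 nM to 100000 nM.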

Compound 4, concentration for 50% growth inhibition: > 50000 nM
Compound 4: a limit, no number (the forecaster's own chance of this, stated with the estimate: 80%); the middle value sits exactly at the limit.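

In this assay compound 4 gives > 50000 nM, which is a limit of the assay and not a number. Going by these compounds alone, compound 1 also sits at a limit, so no step from compound 1 to compound 4 can be read. How far the groups on the shared core change growth inhibition stays open, as all four compounds end at the same limit: the limit of > 50000 nM in this assay, at which 4 of the 4 values shown sit.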